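A few compounds are considered here, and "the series" means these few. Any claim that something is new, unique, unknown or untested is made for them only; others in the source may bear on it.

Measured compounds:
- compound 1, `C/C=C(\C)C(=O)O[C@H]1[C@]2(C)C[C@@H]3O[C@@]1(O)C=C1C4=CC(=O)O[C@@H](c5ccoc5)[C@]4(C)CC[C@@H]1[C@]3(C)[C@@H]2[C@@H](O)C(=O)OC`, in a functional assay on A549 cells (Homo sapiens) for inhibition, read by MTT assay, with a stated time of 24 h (a lower number here means a stronger inhibitor, a higher number a weaker inhibitor), compound 1 gives 8100 nM
- compound 2, `C/C=C(\C)C(=O)O[C@H]1[C@]2(C)C[C@@H]3O[C@@]1(O)C=C1C4=CC(=O)O[C@@H](c5ccoc5)[C@]4(C)CC[C@@H]1[C@]3(C)[C@@H]2C(=O)C(=O)OC`, in this assay compound 2 gives 44400 nM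

Compound 1 stands with the lower of the two numbers, so among these two compounds it is the stronger inhibitor in this assay. Among the measured compounds shown here, the only measured step runs from it: a 5.5-fold higher number from compound 1 to compound 2 (0.74 log units; beyond the scatter). That step concerns a different part of the shared core, a saturated ring carbon bearing the hydroxy(methoxycarbonyl)methyl group, and it does not touch the site changed in the new compound.

The new compound, compound 3, `C/C=C(\C)C(=O)O[C@@H]1[C@]2(OC(=O)CCCC)C=C3C4=CC(=O)O[C@@H](c5ccoc5)[C@]4(C)CC[C@@H]3[C@@]3(C)[C@H](C[C@]1(C)[C@H]3[C@@H](O)C(=O)OC)O2`, differs from compound 1 in one place: butylcarbonyl in place of hydrogen on an oxygen on a saturated carbon. Cut one bond further out, this is hydroxy going to (butylcarbonyl)oxy. For the measured compounds named here, no measured pair shows what adding a butylcarbonyl to this oxygen does in this assay, so the direction of the step is open. With nothing to lean on, the estimate for compound 3 keeps close to its parent, a 1.0-fold lower number from compound 1 to compound 3 (0.01 log units; within the scatter), and is expected to fall within the scatter or only a little beyond it. Compound 3 is therefore estimated at 8000 nM, with a plausible range from 2500 nM to 25000 nM.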

Compound 3, half-maximal inhibitory concentration: 9400 nM
The estimate for compound 3 lay 1.2-fold (0.07 log units) below the measured number; the measured number falls inside the stated range.
By their numbers in this assay, from the lowest: compounds 1 and 3 (each within the scatter of the next); then compound 2.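

In this assay, turning hydroxy into (butylcarbonyl)oxy gives a 1.2-fold higher number from compound 1 to compound 3 (0.06 log units; within the scatter) and so stays within the scatter, which shows that this oxygen on a saturated carbon can carry a group of 6 heavy atoms in place of its hydrogen with no measurable shift in the number. That hydrogen is therefore not needed for the level of inhibition seen in these cells, whereas the change elsewhere on the shared core, a 5.5-fold higher number from compound 1 to compound 2 (0.74 log units; beyond the scatter) and beyond the scatter, does register in the same assay. Nothing available explains why the butylcarbonyl change leaves the number within the scatter.

One group at this oxygen cannot show how far that tolerance extends: a shorter acetyl, a longer chain such as decanoyl, a ring-bearing benzoyl or a simple methyl ether could each behave differently. On these data alone, it also remains open whether butylcarbonyl at this oxygen would give a similar result when combined with the (methoxycarbonyl)carbonyl group of compound 2.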